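Adding a 4-fluorophenyl group to the least stable analogue

This account rests on a few compounds, and the source may have more. Where it says the series, first, only, none or still open, it means among the compounds named here.

Compound 1 `C[C@H](Nc1nc(N)nc(N)c1C#N)c1cc2ccc(F)cn2c(=O)c1-c1ccccc1`: 42%
Compound 2 `C[C@H](Nc1nc(N)ncc1C#N)c1cc2ccc(F)cn2c(=O)c1-c1ccccc1`: 11%
Compound 3 `Cc1nc(N)nc(N[C@@H](C)c2cc3ccc(F)cn3c(=O)c2-c2ccccc2)c1C#N`: 8%

The three compounds share a core and differ only at one aromatic carbon of the aminopyrimidine part. In an ADME assay on microsomes from liver (Mus musculus), read by LC-MS, using NADPH, with a stated time of 30 min, tested at 1 uM (on this read-out higher numbers stand for a more stable compound and lower numbers for a less stable compound), compound 1 gives 42%, and the fall a number 31 percentage points lower from compound 1 to compound 2 (beyond the scatter) and the fall a number 34 percentage points lower from compound 1 to compound 3 (beyond the scatter) both lie beyond the scatter. The change a number 3 percentage points lower from compound 2 to compound 3 (within the scatter) is within the scatter. Compound 3 therefore stands lowest of the three on the numbers shown, though it cannot be separated from compound 2.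

Compound 4 `Cc1nc(N)nc(N[C@@H](C)c2c(-c3ccccc3)c(=O)n3cc(F)ccc3c2-c2ccc(F)cc2)c1C#N` differs from compound 3 by 4-fluorophenyl in place of hydrogen on an aromatic carbon. For the measured compounds named here, none of the measured steps touches this position; all three concern the aminopyrimidine, so there is no direct precedent for the effect of the 4-fluorophenyl group in this assay. Because compound 3 already gives 8%, little room remains downward, and an outcome within the scatter seems the most likely. Compound 4 is therefore expected to show a number 1 percentage points lower from compound 3 to compound 4 (within the scatter). The estimate for compound 4 is 7%, within a range of 1% to 22%.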

Compound 4, percent of the compound remaining: 65%
For compound 4 the middle estimate is 58 percentage points below the measured one; measured number outside the range, above it.
By their numbers in this assay, from the lowest: compounds 3 and 2 (each within the scatter of the next); then compound 1; then compound 4.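

Placing 4-fluorophenyl on this aromatic carbon, ortho to a fused ring, gives a number 57 percentage points higher from compound 3 to compound 4 (beyond the scatter) in this assay, the only step shown at this position. For the compounds shown here, all the earlier steps concerned a single aromatic carbon in another part of the molecule, so this result shows that a second site also moves the read-out, and here a single change moves it upward from one of the two lowest compounds. No measurement shown here explains the rise.

The compounds shown leave open whether the rise requires the fluorine, or whether a plain phenyl group, a cyclopropyl group or a morpholine on this carbon would give a similar number. They also leave open whether 4-fluorophenyl would give a comparable step on compound 1 or compound 2, which carry other groups at the varied aromatic carbon.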